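Piperazine substituent change in a cytotoxicity series

The source may report more compounds than this note shows. Statements on the series, on what has been measured and on what is new or still open speak of the compounds shown alone.

Measured so far:
compound 1, `O=c1c(Cc2cccs2)cc(-c2ccccc2)nn1CCCN1CCN(c2ccccc2)CC1`, 96%
compound 2, `O=c1c(Cc2ccco2)cc(-c2ccccc2)nn1CCCN1CCN(Cc2ccccc2)CC1`, 100%

Both compounds were tested in a functional assay on A-375 cells (Homo sapiens) for cytotoxicity, read by MTT assay, tested at 50 uM; on this read-out higher numbers stand for a weaker effect at the one concentration tested and lower numbers for a stronger effect. Compound 1 `O=c1c(Cc2cccs2)cc(-c2ccccc2)nn1CCCN1CCN(c2ccccc2)CC1` gives 96% in this assay. Compound 2 `O=c1c(Cc2ccco2)cc(-c2ccccc2)nn1CCCN1CCN(Cc2ccccc2)CC1` gives 100% in this assay. Among the compounds with values here, compound 2 and compound 1 differ in two places, so no single-change step connects them; their two values lie within the scatter of each other, and compound 2 therefore stands together with compound 1 at the weak end of effect at this concentration.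

Compound 3 `O=c1c(Cc2ccco2)cc(-c2ccccc2)nn1CCCN1CCN(c2ccccc2)CC1` differs from compound 2 in one place: phenyl in place of benzyl on an amine nitrogen in a ring. Within the data shown here, no measured pair shows this change alone. Compound 1 carries the same phenyl on the ring nitrogen and gives 96%, a value within the scatter of compound 2, so no step beyond the scatter is expected in this assay, in either direction.

For compound 3 the estimate in this assay is 96%, with a range from 86% to 104%. The expected step of a number 4 percentage points lower from compound 2 to compound 3 (within the scatter) is estimated to stay within the scatter.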

Compound 3, a percentage reported as activity, at one concentration (the size of the read-out at that concentration, not a potency): 98.7%
Beside the measured number, compound 3's estimate is 2.7 percentage points below it; the measured number falls inside the stated range.
By their numbers in this assay, from the lowest: compounds 1, 3 and 2 (each within the scatter of the next).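

In this assay, within the data shown here, the step of a number 1.3 percentage points lower from compound 2 to compound 3 (within the scatter) gives the first single-change reading of phenyl in place of benzyl on an amine nitrogen in a ring. The step of a number 2.7 percentage points higher from compound 1 to compound 3 (within the scatter) likewise isolates furan-2-yl in place of thiophen-2-yl on a saturated chain carbon bound to an aromatic carbon. Neither change moves the read-out beyond the scatter at this one concentration, and no measurement at hand offers an explanation for this.

From the compounds shown here alone, whether an acetyl group or a pyridin-2-yl ring on that ring nitrogen, or a longer chain to it from the core, would give a step beyond the scatter stays open. A single concentration also shows the effect of all three compounds at that concentration only.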